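The source may hold more compounds than are shown below. What is called first, only, known or untested is meant among the compounds shown, and "the series" means these compounds.

Values measured in a physicochemical assay for lipophilicity, read by HPLC, at pH 7.5 (a lower number here means a more polar compound, a higher number a more lipophilic compound), for three compounds:
Compound 1 `CC[C@@H](Nc1c(C#N)c(-c2ccc(-c3cccnc3C)cc2)nc2cnccc12)C(N)=O` gives 1.9
Compound 2 `CCOc1ccccc1-c1ccc(-c2nc3cnccc3c(N[C@H](CC)C(N)=O)c2C#N)cc1` gives 3
Compound 3 `CC[C@@H](Nc1c(C#N)c(-c2ccc(-c3ccc(Cl)cc3)cc2)nc2cnccc12)C(N)=O` gives 3.1

Compound 3, at the upper end of this short series, cannot be told apart from compound 2: the data show a number 0.10 log units higher from compound 2 to compound 3 (within the scatter) for that pair. The gap to the remaining compound is far wider, with a number 1.20 log units higher from compound 1 to compound 3 (beyond the scatter) on record.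

Compound 4 `CC[C@@H](Nc1c(C#N)c(-c2ccc(-c3ccccc3C(F)(F)F)cc2)nc2cnccc12)C(N)=O` has not yet been measured. Its difference from compound 3 is 2-(trifluoromethyl)phenyl in place of 4-chlorophenyl on an aromatic carbon, para to a large group.

Two of the measured steps are large, namely a number 1.10 log units higher from compound 1 to compound 2 (beyond the scatter) and a number 1.20 log units higher from compound 1 to compound 3 (beyond the scatter), but both remove the 2-methylpyridin-3-yl group, which plays no part in this change. The closest guide is the exchange of 2-ethoxyphenyl for 4-chlorophenyl, where one ring of carbon only replaces another. Among the compounds with values here, no measured compound carries a trifluoromethyl group, so the comparison is thin. Within the data shown here, on the strength of a number 0.10 log units higher from compound 2 to compound 3 (within the scatter) as the only such exchange, no step beyond the scatter is expected in this assay here. The expected change is a number 0.10 log units higher from compound 3 to compound 4 (within the scatter) on this reading. For compound 4 the estimated value is 3.2, with an expected range from 2.8 to 3.6 as the measurement is awaited.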

Compound 4, distribution coefficient: 3.1
Compound 4: middle estimate off by 0.10 log units, on the high side; low and high end bracket the measured number.
By their numbers in this assay, from the lowest: compound 1; then compounds 2, 3 and 4 (each within the scatter of the next).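

In this assay, the exchange on an aromatic carbon, para to a large group, gives no change at the digits printed from compound 3 to compound 4 (within the scatter) even though the entering 2-(trifluoromethyl)phenyl replaces chlorine with fluorine and carries more heavy atoms than 4-chlorophenyl. Trifluoromethyl in place of ethoxy gives a number 0.10 log units higher from compound 2 to compound 4 (within the scatter) and so adds a third carbon-only aromatic ring to a group of compounds that this measurement cannot separate, with the substituents 2-ethoxyphenyl, 4-chlorophenyl and 2-(trifluoromethyl)phenyl. Within the data shown here, the step with 2-(trifluoromethyl)phenyl in place of 2-methylpyridin-3-yl is a number 1.20 log units higher from compound 1 to compound 4 (beyond the scatter) and shows that compound 1 stands apart from a third partner, with no compound here going against that separation.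

Nothing available here accounts for either the closeness of compounds 2, 3 and 4 or the distance of compound 1. On these data alone, it remains open whether an amine or a carboxylic acid on the same aromatic carbon would give a number near that of compound 1, and whether trifluoromethyl would give the same result at another place on the phenyl ring.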